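Working notes: amide side-chain variation and cytotoxicity

The source may hold more compounds than are shown below. What is called first, only, known or untested is meant among the compounds shown, and "the series" means these compounds.

Measured so far:
- compound 1 `Cn1c(-c2ccc(NC(=O)CCl)cc2)nc(-c2ccccc2)c1-c1ccccc1`: 42.8% in a functional assay on MCF7 cells (Homo sapiens) for cytotoxicity, read by MTT assay, with a stated time of 24 h, tested at 32 ug/mL; on this read-out lower numbers stand for a weaker effect and higher numbers for a stronger effect at the one concentration tested
- compound 2 `Cc1ccc2oc(SCC(=O)Nc3ccc(-c4nc(-c5ccccc5)c(-c5ccccc5)n4C)cc3)nc2c1`: 57.7%
- compound 3 `Cn1c(-c2ccc(NC(=O)CSc3nc4ccccc4s3)cc2)nc(-c2ccccc2)c1-c1ccccc1`: 59%

Compound 2 stands second highest of the three. Its nearest neighbour is compound 3, with a number 1.3 percentage points higher from compound 2 to compound 3 (within the scatter); its furthest is compound 1, the step being a number 14.9 percentage points higher from compound 1 to compound 2 (beyond the scatter).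

The next compound is compound 4 `CCN1CCN(CC(=O)Nc2ccc(-c3nc(-c4ccccc4)c(-c4ccccc4)n3C)cc2)CC1`. The change from compound 2 is 4-ethylpiperazin-1-yl in place of (5-methyl-1,3-benzoxazol-2-yl)sulfanyl on a saturated chain carbon bound to a carbonyl carbon.

Going by the values given here, two measured steps bear on this position: a number 14.9 percentage points higher from compound 1 to compound 2 (beyond the scatter) and a number 16.2 percentage points higher from compound 1 to compound 3 (beyond the scatter) both show that what sits on the saturated chain carbon bound to the carbonyl carbon shifts the read-out modestly, while a number 1.3 percentage points higher from compound 2 to compound 3 (within the scatter) shows that exchanging one heteroaryl on the sulfur for another does nothing beyond the scatter. Among the compounds with values here, no measured step removes the heteroaryl sulfanyl altogether or brings in a saturated amine ring, so the direction for compound 4 rests on no direct precedent. The gain seen on going from chloro to either heteroaryl sulfanyl is not assumed to carry over to the ethylpiperazinyl, so compound 4 is expected to fall back toward the level of compound 1, a step of about a number 15.7 percentage points lower from compound 2 to compound 4 (beyond the scatter). The estimate for compound 4 in this assay is therefore 42%, with a range from 22% to 62%.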

Compound 4, a percentage reported as activity, at one concentration (the size of the read-out at that concentration, not a potency): 38.6%
Compound 4: the middle estimate sits 3.4 percentage points above what was measured; measured number inside the range.
By their numbers in this assay, from the lowest: compounds 4 and 1 (each within the scatter of the next); then compounds 2 and 3 (each within the scatter of the next).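

In this assay, 4-ethylpiperazin-1-yl does not hold the level of either heteroaryl sulfanyl group, with a number 19.1 percentage points lower from compound 2 to compound 4 (beyond the scatter) and a number 20.4 percentage points lower from compound 3 to compound 4 (beyond the scatter) on the same saturated chain carbon bound to a carbonyl carbon. Against chloro, the same change gives a number 4.2 percentage points lower from compound 1 to compound 4 (within the scatter) and so no separation. The four compounds therefore form two groups at this position, compound 1 with compound 4 and compound 2 with compound 3, and nothing measured here accounts for that split.

From the compounds shown here alone, it remains open whether the sulfur or the fused aromatic ring goes with the higher level, a question that a plain phenylsulfanyl on the same carbon would address. Also open, going by these compounds, is whether morpholin-4-yl, or a longer chain carrying the 4-ethylpiperazin-1-yl, would stay with compound 4.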